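This account rests on a few compounds, and the source may have more. Where it says the series, first, only, none or still open, it means among the compounds named here.

Working notes on the series. Compound 3 `Cc1ccc(S(=O)(=O)/N=C(/CCNC2=CC(=O)c3ccccc3C2=O)Nc2ccccc2I)cc1` stands second highest of the three numbers in a functional assay on A549 cells (Homo sapiens) for cytotoxicity, read by MTT assay, with a stated time of 48 h; on this read-out lower numbers stand for stronger inhibition and higher numbers for weaker inhibition; in that read-out compound 3 gives 24700 nM. Compound 1 `COc1ccc(N/C(CCNC2=CC(=O)c3ccccc3C2=O)=N\S(=O)(=O)c2ccc(C)cc2)cc1` in this assay gives 25500 nM, and the step of a 1.0-fold lower number from compound 1 to compound 3 (0.01 log units; within the scatter) lies within the scatter. Among the measured compounds shown here, compound 2 `Cc1ccc(S(=O)(=O)/N=C(/CCNC2=CC(=O)c3ccccc3C2=O)Nc2ccc(F)cc2)cc1` in this assay gives 9330 nM; the step of a 2.6-fold higher number from compound 2 to compound 3 (0.42 log units; beyond the scatter) is the only step beyond the scatter that involves compound 3, and a 2.7-fold lower number from compound 1 to compound 2 (0.44 log units; beyond the scatter) is the other change on the aryl group. Compound 4 `Cc1ccc(S(=O)(=O)/N=C(/CCNC2=CC(=O)c3ccccc3C2=O)Nc2cccc(C)c2)cc1` carries the change (3-methylphenyl in place of 2-iodophenyl on an amine nitrogen). For the measured compounds named here, no measured step involves 3-methylphenyl, and only one of the two steps into compound 3 is beyond the scatter, so no step beyond the scatter is expected in this assay. Compound 4 is estimated at 20000 nM (range 8000 nM to 50000 nM). The expected step is a 1.2-fold lower number from compound 3 to compound 4 (0.09 log units; within the scatter).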

Compound 4, half-maximal inhibitory concentration: 18700 nM
The estimate for compound 4 lay 1.1-fold (0.03 log units) above the measured number; the measured number falls inside the stated range.
By their numbers in this assay, from the lowest: compounds 2, 4, 3 and 1 (each within the scatter of the next, the first and the last beyond it).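

In this assay, among the compounds shown here, 3-methylphenyl on the amine nitrogen is the first aryl group within the scatter of all the others (a 1.3-fold lower number from compound 3 to compound 4 (0.12 log units; within the scatter); a 1.4-fold lower number from compound 1 to compound 4 (0.13 log units; within the scatter); a 2.0-fold higher number from compound 2 to compound 4 (0.30 log units; within the scatter)). The 4-fluorophenyl of compound 2 therefore stands apart from 4-methoxyphenyl and 2-iodophenyl but not from 3-methylphenyl, and swapping iodine at one ring position for methyl at another leaves the number within the scatter. Still open, on these data alone, is whether a carboxylic acid or an amine on this aryl ring, or a cyclohexyl group in its place, would move the number beyond this span. No measurement at hand accounts for these numbers.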